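The compounds below may be only part of what the source reports. "The series", "measured", "known", "first", "only" and "open" are said of these compounds alone.

Compound 1, `CCCNC(=C\C(=O)/C=C/c1ccc(O)c(OC)c1)/C=C/c1ccc(O)c(OC)c1`, is the reference point of this small set. In a functional assay for inhibition, read by spectrophotometry, with a stated time of 30 min, tested at 1 uM (on this read-out lower numbers stand for less inhibition and higher numbers for more inhibition at the one concentration tested (going by the name of the read-out)), compound 1 gives 0.1%, the higher of the two numbers recorded so far. Compound 2, `COc1cc(/C=C/C(=O)/C=C(/C=C/c2ccc(OC(C)=O)c(OC)c2)NCC(C)C)ccc1OC(C)=O`, with acetylated phenols and an isobutyl group on the amine nitrogen, gives 0% in this assay; the two values lie within the scatter of each other, so the two numbers are level. Both sit at the floor of the read-out.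

Compound 3, `COc1cc(/C=C/C(=O)/C=C(/C=C/c2ccc(O)c(OC)c2)NC2CCCCC2)ccc1O`, carries cyclohexyl in place of propyl on an amine nitrogen. Within the data shown here, no step between measured compounds is available to calibrate this change. Because compound 1 gives 0.1% and compound 2 gives 0%, the series shows no inhibition to move from, and the expected step of a number 0.9 percentage points higher from compound 1 to compound 3 (within the scatter) is none beyond the scatter. Compound 3 is therefore expected to give about 1%, estimated within 0% to 10%.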

Compound 3, a percentage reported as inhibition, at one concentration (the size of the read-out at that concentration, not a potency): 0.13%
For compound 3 the middle estimate is 0.9 percentage points above the measured one; the measured number falls inside the stated range.
By their numbers in this assay, from the lowest: compounds 2, 1 and 3 (each within the scatter of the next).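

In this assay, among these compounds, cyclohexyl in place of propyl on an amine nitrogen gives a number 0 percentage points higher from compound 1 to compound 3 (within the scatter), the only step in this set that can be read at a single place. At this position, a six-membered non-aromatic ring of 6 heavy atoms therefore leaves the read-out at the same floor as the 3 heavy atoms of propyl, so the larger ring brings out no inhibition at the one concentration tested. No measured evidence bears on this result, and no reason for it can be offered.

With the values at the floor, this read-out cannot yet separate one group on this nitrogen from another. Open, going by these compounds, is whether a benzyl group, or a propyl chain ending in an amine or a carboxylic acid, would lift the number beyond the scatter.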